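Swapping the Aminopropyl Chain for a Carbamoyl Group

The compounds below may be only part of what the source reports. "The series", "measured", "known", "first", "only" and "open" are said of these compounds alone.

Of the compounds shown here, three sharing one core have been tested in a functional assay on the whole organism (Tail, strain ICR) with Mus musculus as the target, in the tail flick test, with a stated time of 120 min, at a dose of 25 umol/kg by the oral route; a higher number here means a stronger effect of the compound at the dose given, a lower number a weaker effect. Compound 1, `O=C(CN(c1nc(Cl)nc2[nH]cnc12)C1CC1)N[C@@H](CO)C(=O)OCc1ccccc1`, gives 34.5%. Compound 2, `O=C(CN(c1nc(Cl)nc2[nH]cnc12)C1CC1)N[C@@H](CCC(=O)OCc1ccccc1)C(=O)OCc1ccccc1`, gives 45.9%. Compound 3, `NCCCC[C@H](NC(=O)CN(c1nc(Cl)nc2[nH]cnc12)C1CC1)C(=O)OCc1ccccc1`, gives 16.8%, the lowest of the three numbers. Both steps leading to it fall: a number 17.7 percentage points lower from compound 1 to compound 3 (beyond the scatter) and a number 29.1 percentage points lower from compound 2 to compound 3 (beyond the scatter), while between the other two a number 11.4 percentage points higher from compound 1 to compound 2 (beyond the scatter).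

Compound 4, `NC(=O)C[C@H](NC(=O)CN(c1nc(Cl)nc2[nH]cnc12)C1CC1)C(=O)OCc1ccccc1`, is not yet measured. It differs from compound 3 in one place: carbamoyl in place of 3-aminopropyl on a saturated chain carbon, two bonds along the chain from an amide-type nitrogen and a carbonyl carbon. The leaving and the entering group each carry no net charge, yet the leaving group is the one whose arrival brought the drop in both steps to compound 3. For the measured compounds named here, no measured step shows what a carbamoyl group does here, so the expectation rests on the size of that drop. Removing the 3-aminopropyl group is expected to recover part of it, giving a number 13.2 percentage points higher from compound 3 to compound 4 (beyond the scatter). Compound 4 is therefore estimated at 30%, with a range from 15% to 45%.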

Compound 4, a percentage reported as activity, at one dose (the size of the read-out at that dose, not a potency): 15.1%
The estimate for compound 4 lay 14.9 percentage points above the measured number, within the range that was stated.
By their numbers in this assay, from the lowest: compounds 4 and 3 (each within the scatter of the next); then compound 1; then compound 2.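

In this assay compound 4 shows that carbamoyl on this saturated chain carbon cannot be told apart from 3-aminopropyl (a number 1.7 percentage points lower from compound 3 to compound 4 (within the scatter)), so the low number of compound 3 is not unique to the 3-aminopropyl group. Carbamoyl also stays well short of the other two groups, (benzyloxycarbonyl)methyl (a number 30.8 percentage points lower from compound 2 to compound 4 (beyond the scatter)) and hydroxy (a number 19.4 percentage points lower from compound 1 to compound 4 (beyond the scatter)), which leaves those two as the only groups shown here with clearly higher numbers. Nothing available explains why these groups give these numbers.

As far as these compounds go, a carboxylic acid in place of carbamoyl remains open, as does a longer chain ending in carbamoyl. From the compounds shown here alone, it is also open whether a plain benzyl group or a simple methyl at this carbon would match compound 2 or fall to the level of compound 4.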